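A few compounds are considered here, and "the series" means these few. Any claim that something is new, unique, unknown or untested is made for them only; others in the source may bear on it.

Of the compounds shown here, two built on a shared core have been tested in a functional assay on the whole organism (artery, strain albino) with Rattus norvegicus as the target, with a stated time of 240 min, at a dose of 10 mg/kg by the oral route; on this read-out lower numbers stand for less inhibition and higher numbers for more inhibition at the one dose given (going by the name of the read-out). Compound 1 `CC1=C(C(=O)Nc2ccc(F)cc2)C(c2ccc([N+](=O)[O-])cc2)N=C(SCc2ccc(Cl)cc2)N1` gives 33.3%. Compound 2 `CC1=C(C(=O)Nc2ccc(Br)cc2)C(c2ccc(Cl)cc2Cl)N=C(SCc2ccccc2)N1` gives 17.4%, the lower of the two numbers, and the gap to compound 1 lies beyond the usual scatter. Compound 3 `CC1=C(C(=O)Nc2ccc(Br)cc2)C(c2ccc(Cl)cc2Cl)N=C(SCc2ccc(F)cc2)N1` differs from compound 2 in one place: fluoro in place of hydrogen on an aromatic carbon. Among the measured compounds shown here, no measured pair shows this change on its own, so the numbers give no direct guide to its size. In this assay the step is expected to be a number 2.6 percentage points higher from compound 2 to compound 3 (within the scatter), no larger than the scatter in either direction. Compound 3 is therefore expected to give about 20%, between 5% and 40%.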

Compound 3, a percentage reported as inhibition, in the whole organism at one dose (the size of the read-out at that dose, not a potency): 36.4%
Compound 3: middle estimate off by 16.4 percentage points, on the low side; measured number inside the range.
By their numbers in this assay, from the lowest: compound 2; then compounds 1 and 3 (each within the scatter of the next).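

In this assay, going from benzylsulfanyl to (4-fluorobenzyl)sulfanyl gives a number 19 percentage points higher from compound 2 to compound 3 (beyond the scatter). This shows that this position responds to a change as small as one fluoro, para to a large group, at least with the rest of compound 2 held fixed. Nothing available explains why the number moves. As far as these compounds go, whether methoxy or an amine in place of the fluoro would give a larger or smaller step remains open. So does whether the fluoro step would hold with different groups elsewhere on the shared core.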